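The compounds below may be only part of what the source reports. "The series", "measured", "known", "first", "only" and "open" are said of these compounds alone.

Measured compounds:
compound 1 `COc1cc(C(=O)N/N=C/c2c(Cl)cccc2Cl)cc(OC)c1OC` gives 52.1% in a functional assay on PC-3 cells (Homo sapiens) for antiproliferative activity, read by MTT assay, tested at 5 uM; a lower number here means a weaker effect, a higher number a stronger effect of the compound at the concentration tested
compound 2 `COc1cc(C2=NN(C(C)=O)C(c3ccc(C(F)(F)F)cc3)O2)cc(OC)c1OC` gives -0.7%

Going by the values given here, compound 1 stands highest of the two numbers measured; compound 2 lies far below it, beyond the scatter, and no step between them is drawn here. The next compound, compound 3 `COc1cc(C(=O)N/N=C/c2ccc(Cl)c(Cl)c2)cc(OC)c1OC`, keeps the core of compound 1 and rearranges the chlorines on one ring: 3,4-dichlorophenyl in place of 2,6-dichlorophenyl on a carbon with a double bond to nitrogen. With no measured step of this kind in hand, the expectation for compound 3 is a modest step downward a number 12.1 percentage points lower from compound 1 to compound 3 (beyond the scatter), roughly at the edge of the scatter. Compound 3 is expected to give 40%, with a range from 10% to 68%.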

Compound 3, a percentage reported as inhibition, at one concentration (the size of the read-out at that concentration, not a potency): 31.6%
Compound 3: the middle estimate sits 8.4 percentage points above what was measured; low and high end bracket the measured number.
By their numbers in this assay, from the lowest: compound 2; then compound 3; then compound 1.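

In this assay the change from 2,6-dichlorophenyl to 3,4-dichlorophenyl on the carbon with a double bond to nitrogen gives a number 20.5 percentage points lower from compound 1 to compound 3 (beyond the scatter) with the same atoms in both compounds, so the read-out responds to the arrangement of the chlorines alone. Going by these compounds alone, this is the first single-place comparison, and the effect is reduced rather than lost. No measurement at hand explains the drop.

Open, from the compounds shown here alone, is how a single chlorine, or a nitrile or an amine on this phenyl ring, would compare. Whether the shift comes from leaving the 2,6-dichlorophenyl group or from entering the 3,4-dichlorophenyl group also remains unresolved.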